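Halogen swap on the aryl amine of compound 1

This account rests on a few compounds, and the source may have more. Where it says the series, first, only, none or still open, it means among the compounds named here.

Measured so far:
Compound 1 `O=C1C=C(Nc2ccc(I)cc2)C(=O)c2c1nc1n2[C@H]2OC[C@@H](O)[C@H]2OC1` — 4070 nM
Compound 2 `CCOc1ccc(NC2=CC(=O)c3c(nc4n3[C@H]3OC[C@@H](O)[C@H]3OC4)C2=O)cc1` — 14400 nM
Compound 3 `COc1ccccc1NC1=CC(=O)c2c(nc3n2[C@H]2OC[C@@H](O)[C@H]2OC3)C1=O` — 7460 nM

Of the compounds shown here, three sharing one core have been tested in a functional assay on HeLa cells (Homo sapiens) for inhibition, read by sulforhodamine B assay; a lower number here means a stronger inhibitor, a higher number a weaker inhibitor. Compound 1 gives the lowest number of the three; against compound 3 the gap is within the scatter, while against compound 2 it lies beyond it. Among the measured compounds shown here, the only single-point step among them, a 1.9-fold lower number from compound 2 to compound 3 (0.29 log units; within the scatter), stays within the scatter.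

Compound 4 `O=C1C=C(Nc2cccc(Cl)c2)C(=O)c2c1nc1n2[C@H]2OC[C@@H](O)[C@H]2OC1` has not been measured. Its change from compound 1 is 3-chlorophenyl in place of 4-iodophenyl on an amine nitrogen. For the measured compounds named here, no measured step exchanges one halogen for another, so the step from compound 2 to compound 3 bears on it only as a sign that a change of the aryl substituent on the amine nitrogen can leave this assay little moved. On that basis the step from compound 1 to compound 4 is expected to be small, a 1.2-fold higher number from compound 1 to compound 4 (0.09 log units; within the scatter), not beyond the scatter in either direction. Compound 4 is therefore estimated at 5000 nM, within a range from 2000 nM to 12500 nM.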

Compound 4, half-maximal inhibitory concentration: 6040 nM
Compound 4: middle estimate off by 1.2-fold (0.08 log units), on the low side; measured number inside the range.
By their numbers in this assay, from the lowest: compounds 1, 4, 3 and 2 (each within the scatter of the next, the first and the last beyond it).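

In this assay, among the compounds shown here, the change from 4-iodophenyl to 3-chlorophenyl on the amine nitrogen gives a 1.5-fold higher number from compound 1 to compound 4 (0.17 log units; within the scatter) and is the first measured exchange of one halogen for another at this position. It shows that such a change, made to a group of the same heavy-atom count, can leave this assay within the scatter, yet the halogen and its place on the ring differ in the same step, so this step cannot tell their contributions apart.

A 4-chlorophenyl or 3-iodophenyl group would separate those two changes, while an unsubstituted phenyl group, a carboxylic acid on the ring or a saturated cyclohexyl group in place of the aryl ring would test how far this position can be altered. No evidence is available to explain the size of the step.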